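This account rests on a few compounds, and the source may have more. Where it says the series, first, only, none or still open, it means among the compounds named here.

Measured compounds:
Compound 1 `CCCCCCCCc1ccc(NC(=O)Nc2c(C(C)C)cccc2C(C)C)cc1`: in an assay on isolated protein for inhibition of acyl-CoA:cholesterol acyltransferase (Oryctolagus cuniculus) (a lower number here means a stronger inhibitor, a higher number a weaker inhibitor), compound 1 gives 11 nM.
Compound 2 `CCCc1ccc(NC(=O)Nc2c(C(C)C)cccc2C(C)C)cc1`: in this assay compound 2 gives 38 nM.
Compound 3 `CCCCc1ccc(NC(=O)Nc2c(C(C)C)cccc2C(C)C)cc1`: in this assay compound 3 gives 29 nM.

Compound 3 stands second highest of the three numbers. Its nearest neighbour is compound 2, within the scatter (a 1.3-fold lower number from compound 2 to compound 3 (0.12 log units; within the scatter)); its furthest is compound 1, with a 2.6-fold higher number from compound 1 to compound 3 (0.42 log units; beyond the scatter), a step beyond the scatter.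

Compound 4 `CCCCCCCCCCCCc1ccc(NC(=O)Nc2c(C(C)C)cccc2C(C)C)cc1` differs from compound 3 by octyl in place of hydrogen on a saturated chain carbon, four bonds along the chain from an aromatic carbon. Among the measured compounds shown here, the step that bears on this change is the one from compound 1 to compound 3, where butyl leaving at this same place gave a 2.6-fold higher number from compound 1 to compound 3 (0.42 log units; beyond the scatter); the step of a 3.5-fold higher number from compound 1 to compound 2 (0.54 log units; beyond the scatter) points the same way. Both say that a longer chain at this position goes with a lower number, modestly. Octyl entering, however, reaches well past the chain of compound 1, and no measured pair shows whether the trend continues that far; the expectation therefore rests on compound 1 as the anchor. For compound 4 the expected step in this assay is a 2.9-fold lower number from compound 3 to compound 4 (0.46 log units; beyond the scatter). Compound 4 is estimated at 10 nM, with a range of 4 nM to 30 nM in this assay.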

Compound 4, half-maximal inhibitory concentration: 15 nM
Compound 4: the middle estimate sits 1.5-fold (0.18 log units) below what was measured; the range from low to high includes it.
By their numbers in this assay, from the lowest: compounds 1, 4, 3 and 2 (each within the scatter of the next, the first and the last beyond it).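

In this assay, among the compounds shown here, octyl entering on compound 3 gives no step that clears the scatter (a 1.9-fold lower number from compound 3 to compound 4 (0.29 log units; within the scatter)). For the compounds shown here, compound 4 also cannot be told apart from compound 1 (a 1.4-fold higher number from compound 1 to compound 4 (0.13 log units; within the scatter)), so the trend of lower numbers with longer chains, read from the earlier compounds, shows no further measurable step past the chain of compound 1; only the comparison with the short chain of compound 2 lies beyond the scatter (a 2.5-fold lower number from compound 2 to compound 4 (0.40 log units; beyond the scatter)). No evidence available here explains this levelling of the numbers.

As far as these compounds go, whether a still longer chain would hold the number level or raise it remains open. Also open, from the compounds shown here alone, is how a chain ending in a carboxylic acid or an amine would read at this place.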